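Fluoro for trifluoromethyl in two benzimidazole-type series

The source may report more compounds than this note shows. Statements on the series, on what has been measured and on what is new or still open speak of the compounds shown alone.

Compound 1 `Fc1ccc(-c2nc3cnc(Nc4ccccn4)cc3[nH]2)cc1C(F)(F)F` and compound 2 `Fc1ccc(-c2nc3cnc(Nc4ccccn4)cc3[nH]2)cc1F` share one core; compound 3 `FC1(F)CCC(c2nc3cnc(Nc4ccc(C(F)(F)F)cn4)cc3[nH]2)CC1` carries another. The difference between the two cores is not broken down here. In a physicochemical assay for solubility, using the shake flask method, in simulated intestinal fluid, measured as kinetic solubility, with a stated time of 20 h, at pH 6.5 (on this read-out lower numbers stand for lower solubility and higher numbers for higher solubility), compound 1 gives >= 50000 nM, which is a limit of the assay and not a number. Compound 2 also gives a limit, >= 50000 nM, and not a number. Within the data shown here, compound 3 gives 93000 nM, the one value in the set that is a number.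

The change from compound 1 to compound 2 is fluoro in place of trifluoromethyl on an aromatic carbon. Its step, a step that the two limits leave unreadable from compound 1 to compound 2, stays unreadable because the limit of >= 50000 nM in this assay, at which 2 of the 3 values shown sit, covers both compound 1 and compound 2.

Compound 4 `Fc1ccc(Nc2cc3[nH]c(C4CCC(F)(F)CC4)nc3cn2)nc1` has not yet been measured. It differs from compound 3 by fluoro in place of trifluoromethyl on an aromatic carbon. This is the same kind of change as from compound 1 to compound 2, though the surroundings differ: in compound 1 the group sits on a six-membered aromatic ring of carbon only, ortho to a fluoro group and meta to a large group, whereas in compound 3 it sits on a six-membered aromatic ring with one nitrogen, two atoms from the ring nitrogen and para to a large group.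

The measured pair gives no size for this change, so the expectation rests on compound 3 and its value 93000 nM alone. Compound 4 is expected to give 120000 nM in this assay, with a range from 50000 nM to 300000 nM. The estimated step is a 1.3-fold higher number from compound 3 to compound 4 (0.11 log units; within the scatter), expected to lie within the usual scatter.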

Compound 4, solubility: 170000 nM
Compound 4: the middle estimate sits 1.4-fold (0.15 log units) below what was measured; low and high end bracket the measured number.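

In this assay, fluoro in place of trifluoromethyl on an aromatic carbon gives a 1.8-fold higher number from compound 3 to compound 4 (0.26 log units; within the scatter), so on this core the two values cannot be told apart. This is a single pair, on a six-membered aromatic ring with one nitrogen, and it gives no sign of whether the change would read the same on the six-membered aromatic ring of carbon only in the core of compound 1. The change cannot be compared between the two cores, because the matching step on the core of compound 1 cannot be read: the limit of >= 50000 nM in this assay, at which 2 of the 4 values shown sit.

The compounds shown leave open whether another group on that aromatic carbon, such as a nitrile, a methoxy group or an amine, would give a step beyond the scatter in this assay. Also open, from the compounds shown here alone, is whether a carboxylic acid or a longer chain at that place would give a step of similar size on both cores, and so whether any change at this carbon carries from one core to the other.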